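This account rests on a few compounds, and the source may have more. Where it says the series, first, only, none or still open, it means among the compounds named here.

The study compares two closely related ureas in a functional assay on NCI-H322M cells (Homo sapiens) for inhibition, read by sulforhodamine B assay, with a stated time of 48 h, tested at 0.1 uM; a lower number here means a stronger effect, a higher number a weaker effect of the compound at the concentration tested. Compound 2, `COc1cc(Cl)cc(-c2nn(-c3cccc(NC(=O)Nc4ccc(Cl)c(C(F)(F)F)c4)c3)cc2-c2ccncc2)c1`, gives 98% in this assay. For the measured compounds named here, the only other measured compound, compound 1, `O=C(Nc1cccc(-n2cc(-c3ccncc3)c(-c3cc(O)cc(Cl)c3)n2)c1)Nc1ccc(Cl)c(Cl)c1`, gives 88% in this assay. Going by the values given here, of the two numbers, compound 2 is the higher one, but the gap to compound 1 falls within the usual scatter of this assay, so the two compounds cannot be separated on these data, and no step between them is recorded.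

Compound 3, `COc1cc(Cl)cc(-c2nn(-c3cccc(NC(=O)Nc4ccc(Cl)c(Cl)c4)c3)cc2-c2ccncc2)c1`, has not yet been measured. It differs from compound 2 in one place: chloro in place of trifluoromethyl on an aromatic carbon. Among the compounds with values here, nothing among the measured compounds shows what this change does in this assay, so the expectation for compound 3 rests on the value of compound 2 alone. The step from compound 2 to compound 3 is expected to be a number 3 percentage points lower from compound 2 to compound 3 (within the scatter), that is, nothing beyond the scatter. On that basis compound 3 is estimated to give 95% in this assay, with a range from 82% to 105%.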

Compound 3, a percentage reported as activity, at one concentration (the size of the read-out at that concentration, not a potency): 90%
Compound 3: middle estimate off by 5 percentage points, on the high side; low and high end bracket the measured number.
By their numbers in this assay, from the lowest: compounds 1, 3 and 2 (each within the scatter of the next).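

In this assay, for the compounds shown here, the exchange of chloro for trifluoromethyl on an aromatic carbon, ortho to a chloro group and meta to a large group, can now be read directly for the first time. It gives a number 8 percentage points lower from compound 2 to compound 3 (within the scatter) and so does not separate the 4-chloro-3-(trifluoromethyl)phenyl urea from the 3,4-dichlorophenyl urea at this one concentration. Compound 3 also joins compound 1 to compound 2 through single changes: methyl in place of hydrogen on an oxygen on an aromatic ring gives a number 2 percentage points higher from compound 1 to compound 3 (within the scatter) and likewise separates nothing, while the data offer no explanation for either step.

The compounds shown leave open whether any group at this aromatic carbon, such as an amine, a carboxylic acid or a longer chain, would move the number beyond the scatter, since only trifluoromethyl and chloro are seen there. They also leave open whether replacing the methyl on the oxygen with a longer chain would matter, and whether the two changes would stay as small on a different partner group within the shared core.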